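The source may hold more compounds than are shown below. What is called first, only, known or untested is meant among the compounds shown, and "the series" means these compounds.

Measured compounds:
compound 1, `CCOC(=N)CCNc1cc(OC)c(Oc2cccc(C(F)(F)F)c2)c2c(C)ccnc12`, with 1970 nM in a functional assay on T47D cells (Homo sapiens) for cytotoxicity, read by trypan blue exclusion; on this read-out higher numbers stand for weaker inhibition and lower numbers for stronger inhibition.
compound 2, `COc1cc(NCc2cnc[nH]2)c2nccc(C)c2c1Oc1cccc(C(F)(F)F)c1`, with 1280 nM in this assay.

Among these two numbers compound 1 has the highest, and its nearest neighbour is compound 2, which differs from it by a 1.5-fold lower number from compound 1 to compound 2 (0.19 log units; within the scatter). That step exchanges the open chain for one small aromatic ring on the same carbon, and the number barely moved.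

Compound 3, `COc1cc(NCc2ccco2)c2nccc(C)c2c1Oc1cccc(C(F)(F)F)c1`, has not been measured. It differs from compound 1 by a group of 5 heavy atoms (4 carbon, 1 oxygen; one five-membered aromatic ring with 1 hetero atom) in place of a group of 6 heavy atoms (4 carbon, 1 nitrogen, 1 oxygen; no ring), on a saturated chain carbon bound to a nitrogen on an aromatic ring. Among the compounds with values here, the only measured step that bears on this change is the one from compound 1 to compound 2, which also put a small aromatic ring in place of the same open chain and stayed within the scatter. On that basis no step beyond the scatter is expected in this assay; the estimated change is a 1.3-fold lower number from compound 1 to compound 3 (0.12 log units; within the scatter). For compound 3 the expected value is 1500 nM, within a range from 600 nM to 4000 nM.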

Compound 3, half-maximal inhibitory concentration: 15.6 nM
Compound 3: middle estimate off by 96-fold (1.98 log units), on the high side; the whole stated range lies above it.
By their numbers in this assay, from the lowest: compound 3; then compounds 2 and 1 (each within the scatter of the next).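

In this assay this position proves far from indifferent to what it carries: furan-2-yl in place of the open chain gives a 130-fold lower number from compound 1 to compound 3 (2.10 log units; beyond the scatter). The closer comparison is between the two five-membered aromatic rings on the same saturated chain carbon, where furan-2-yl in place of 1H-imidazol-5-yl gives an 82-fold lower number from compound 2 to compound 3 (1.91 log units; beyond the scatter), so among these compounds a small aromatic ring alone does not bring the low number; the identity of the ring matters. Nothing available here accounts for the large difference between these two rings.

The compounds shown leave open whether furan-2-yl is unusual or whether other rings on this carbon, such as thiophen-2-yl or phenyl, would also give a low number. They also leave open how a furan-2-yl ring would fare at the end of a longer chain.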